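Swapping 2-methoxyethoxy for fluoro on the stilbene-like core

The source may hold more compounds than are shown below. What is called first, only, known or untested is meant among the compounds shown, and "the series" means these compounds.

Compound 1 `COCCOc1cc(/C=C/c2ccc3ccccc3c2)ccc1OC`: 2990 nM
Compound 2 `COCCOc1cc(/C=C\c2ccc3ccccc3c2)ccc1OC`: 2990 nM

In a functional assay on P388 cells (Mus musculus) for inhibition (on this read-out lower numbers stand for stronger inhibition and higher numbers for weaker inhibition), compound 1, at 2990 nM, stands level with compound 2, at 2990 nM. The next compound to be tested is compound 3 `COc1ccc(/C=C/c2ccc3ccccc3c2)cc1F`, which keeps the core of compound 1 but carries a different group: fluoro in place of 2-methoxyethoxy on an aromatic carbon. Going by the values given here, only one measured step exists, no change at the digits printed from compound 1 to compound 2 (within the scatter), and it stays within the scatter. It bears only on (the fact that compounds 1 and 2 differ only in the configuration as drawn), so it says nothing about replacing a group on the aromatic carbon. Among the compounds with values here, with no measured step to set a size or direction, no shift beyond the scatter is expected in this assay, though the uncertainty is wide. The expected step is a 1.1-fold lower number from compound 1 to compound 3 (0.03 log units; within the scatter). For compound 3 the estimated value is 2800 nM, with an expected range from 700 nM to 11000 nM.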

Compound 3, half-maximal inhibitory concentration: 4490 nM
Estimate against measurement, compound 3: 1.6-fold (0.21 log units) below; measured number inside the range.
By their numbers in this assay, from the lowest: compounds 1, 2 and 3 (each within the scatter of the next).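

In this assay, going by these compounds alone, replacing 2-methoxyethoxy with fluoro on the aromatic carbon ortho to a methoxy group gives a 1.5-fold higher number from compound 1 to compound 3 (0.18 log units; within the scatter), the first measured change of the group at this position. A chain of 5 heavy atoms with 2 hydrogen-bond acceptors thus gives way to a single fluorine with 0 acceptors, and the number stays within the scatter, so keeping the chain is not needed to hold this read-out at this level. No information given here accounts for this step.

The compounds shown leave open whether another group at this position, such as an amine, a carboxylic acid or a longer ether chain, would move the number beyond the scatter. They also leave open whether the double-bond configuration matters with fluoro in place, as the only E and Z pair shown carries 2-methoxyethoxy.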